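The source may hold more compounds than are shown below. What is called first, only, known or untested is meant among the compounds shown, and "the series" means these compounds.

Working notes on the series. Compound 1 `CCOC(=O)Cn1ncc2c(Nc3ccc(NC(=O)CCl)cc3)ncnc21` carries a (chloromethyl)carbonyl on the aniline nitrogen; in a functional assay on cells (Homo sapiens) for inhibition, read by MTT assay, with a stated time of 72 h (a higher number here means a weaker inhibitor, a lower number a stronger inhibitor), compound 1 gives 7.27 ug/mL. Compound 3 `CCOC(=O)Cn1ncc2c(Nc3ccc(NS(=O)(=O)c4ccccc4)cc3)ncnc21` carries a phenylsulfonyl on that nitrogen instead. For compound 3 the assay reports only a limit, > 100 ug/mL. The step of an at least 13-fold higher number from compound 1 to compound 3 (1.13 log units; beyond the scatter) is large, read against the limit (the limit of > 100 ug/mL in this assay, at which 1 of the 3 values shown sits). Compound 2 `CCOC(=O)Cn1ncc2c(Nc3ccc(NS(=O)(=O)c4ccc([N+](=O)[O-])cc4)cc3)ncnc21` adds a nitro to the phenylsulfonyl ring of compound 3. For compound 2 the assay likewise reports only a limit, > 64 ug/mL. The step that the two limits leave unreadable from compound 2 to compound 3 runs between two limits, the limit of > 64 ug/mL in this assay, at which 1 of the 3 values shown sits, and (the limit of > 100 ug/mL in this assay, at which 1 of the 3 values shown sits), and its size cannot be read.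

Compound 4 `O=C(O)Cn1ncc2c(Nc3ccc(NS(=O)(=O)c4ccc([N+](=O)[O-])cc4)cc3)ncnc21` differs from compound 2 by hydrogen in place of ethyl on an oxygen next to a carbonyl group. Neither measured step touches this ester: one concerns the group on the aniline nitrogen, the other the nitro on the sulfonyl ring. Compound 2 itself stands at a limit, so there is no number to step from. The step that the limit leaves unreadable from compound 2 to compound 4 is therefore expected to be none beyond the scatter, with wide uncertainty. Compound 4 is expected to give about 100 ug/mL, within 30 ug/mL to 300 ug/mL, most probably reported again as a limit.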

Compound 4, half-maximal inhibitory concentration: > 100 ug/mL
Compound 4: no number, only a limit; the forecaster's own chance of this, stated with the estimate: 75%; the middle value sits exactly at the limit.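

In this assay compound 4 gives only a limit, > 100 ug/mL. Among these compounds, compound 2 also stands at a limit, so no step between compound 2 and compound 4 can be read. The compounds shown leave open whether carboxy in place of ethoxycarbonyl changes the read-out at all.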